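Cyclobutyloxy replaced by methyl on the pyrimidine carbon

The source may hold more compounds than are shown below. What is called first, only, known or untested is meant among the compounds shown, and "the series" means these compounds.

Among the compounds with values here, compound 2 `Cc1nc(C)n(CC(=O)N2CCN(c3sc(C(F)(F)F)nc3-c3cnc(OC4CCC4)nc3)C[C@H]2C)n1` sits at the top end of the two values so far in an assay on blood for inhibition of C-X-C chemokine receptor type 3 (Homo sapiens), with a stated time of 30 min (a lower number here means a stronger inhibitor, a higher number a weaker inhibitor), at 306 nM, but compound 1 `Cc1nc(C)n(CC(=O)N2CCN(c3sc(C(F)(F)F)nc3-c3cnc(OC(C)C)nc3)C[C@H]2C)n1` at 216 nM is not separated from it, since the step of a 1.4-fold higher number from compound 1 to compound 2 (0.15 log units; within the scatter) lies within the scatter. The next change gives compound 3 `Cc1ncc(-c2nc(C(F)(F)F)sc2N2CCN(C(=O)Cn3nc(C)nc3C)[C@H](C)C2)cn1` and reads (methyl in place of cyclobutyloxy on an aromatic carbon). Within the data shown here, the one measured step, a 1.4-fold higher number from compound 1 to compound 2 (0.15 log units; within the scatter), exchanges one alkyl on the ether oxygen for another and leaves the oxygen in place, so it bears on the new step only loosely; no measured pair shows the ether removed altogether. The new change cuts the group down to a single carbon, and the expectation is a moderately higher number in this assay, a 2.3-fold higher number from compound 2 to compound 3 (0.36 log units; beyond the scatter), with wide uncertainty. The estimated value for compound 3 is 700 nM, in a range from 200 nM to 2500 nM.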

Compound 3, half-maximal inhibitory concentration: 610 nM
The estimate for compound 3 lay 1.1-fold (0.06 log units) above the measured number; the measured number falls inside the stated range.
By their numbers in this assay, from the lowest: compounds 1, 2 and 3 (each within the scatter of the next, the first and the last beyond it).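

In this assay, this position now has a replacement without the ether oxygen, and methyl in place of cyclobutyloxy cannot be separated from the parent (a 2.0-fold higher number from compound 2 to compound 3 (0.30 log units; within the scatter)). Methyl in place of isopropoxy gives the only step in the series beyond the scatter, and it is modest (a 2.8-fold higher number from compound 1 to compound 3 (0.45 log units; beyond the scatter)), so the reading depends on which ether serves as the reference. Nothing available explains either step, and no supporting data bear on this result.

Open, on these data alone, is whether an amine such as dimethylamino, a hydroxyl group or a longer chain such as butyl on this aromatic carbon would stay in the same range. Also open, as far as these compounds go, is whether an alkoxy group smaller than isopropoxy, such as methoxy, would give a lower number than these three compounds.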